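Chloro in place of methyl: expecting compound 3

This account rests on a few compounds, and the source may have more. Where it says the series, first, only, none or still open, it means among the compounds named here.

compound 1 `COc1cc(-n2cnc3ccc(-c4cccc(Cl)c4)cc32)cc(OC)c1OC` gives 7050 nM
compound 2 `COc1cc(-n2cnc3ccc(-c4ccc(C)cc4)cc32)cc(OC)c1OC` gives 1940 nM

Both values come from a functional assay on A549 cells (Homo sapiens) for antiproliferative activity, read by MTT assay, with a stated time of 72 h; on this read-out higher numbers stand for weaker inhibition and lower numbers for stronger inhibition. Among the measured compounds shown here, of the two numbers there, compound 2 stands lowest at 1940 nM, and compound 1 is its only neighbour. The next compound, compound 3 `COc1cc(-n2cnc3ccc(-c4ccc(Cl)cc4)cc32)cc(OC)c1OC`, carries chloro in place of methyl on an aromatic carbon, para to a large group, so that 4-methylphenyl becomes 4-chlorophenyl (chloro in place of methyl on an aromatic carbon). For the measured compounds named here, one measured step bears on this change: a 3.6-fold lower number from compound 1 to compound 2 (0.56 log units; beyond the scatter). That step alters both the group and its place, so it does not isolate the swap. Going by the values given here, it shows only that compound 1, which bears 3-chlorophenyl, has the higher number. Among the compounds with values here, no measured pair exchanges methyl for chloro at a single place. A small rise in this assay is therefore expected, smaller than the measured step. The estimated change is a 1.5-fold higher number from compound 2 to compound 3 (0.19 log units; within the scatter), and it may not clear the scatter. Compound 3 is expected at an estimated 3000 nM, with a range from 1100 nM to 8500 nM, and the measurement is still to come.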

Compound 3, half-maximal inhibitory concentration: > 10000 nM
Compound 3: a limit, no number; the forecaster's own chance of this, stated with the estimate: 3%; middle value at least 3.3-fold (0.52 log units) from the limit.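

Exchanging methyl for chloro at this one place, para to a large group, had no single-place measurement before, and here the change in this assay is beyond the scatter: an at least 5.1-fold higher number from compound 2 to compound 3 (0.71 log units; beyond the scatter). This also shows that the chloro group at this place does not keep the number of the 4-methylphenyl compound, and that the earlier gap between compound 1 and compound 2 did not rest on the place of the chloro group alone, since the step between the two chloro compounds is only a floor that does not clear the scatter, and their order stays unsettled: an at least 1.4-fold higher number from compound 1 to compound 3 (0.15 log units; that floor lies within the scatter). Compound 3 gives > 10000 nM, which is a limit of the assay and not a number, so the size of both steps stays unknown: the limit of > 10000 nM in this assay, at which 1 of the 3 values shown sits.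

The compounds shown leave open how far past that limit compound 3 lies, and so how large the swap from methyl to chloro really is. They also leave open whether an ethyl group, an amine or a carboxylic acid at this place would hold the number of compound 2, 1940 nM, or lose it as chloro does.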